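This account rests on a few compounds, and the source may have more. Where it says the series, first, only, none or still open, it means among the compounds named here.

Two compounds of the series have numbers in an ADME assay on the whole organism (Macaca fascicularis) for pharmacokinetics, at a dose of 0.3 mg/kg by the oral route; a lower number here means less compound in the circulation, a higher number more compound in the circulation at the dose given. Compound 1 `Cc1ccc(-c2nc(=O)o[nH]2)c(-c2ccc([C@@H](C)N(CC3CC3)c3nc(C(=O)NS(=O)(=O)C4CC4)c(C4CC4)s3)cc2)c1` gives 10200 ng.h/mL. Within the data shown here, compound 2 `CONC(=O)c1ccc(Cl)cc1-c1ccc([C@@H](C)N(CC2CC2)c2nc(C(=O)NS(=O)(=O)C3CC3)c(C3CC3)s2)cc1` gives 3290 ng.h/mL, the lower of the two numbers; its only neighbour, compound 1, stands beyond the scatter above it. Among the measured compounds shown here, no pair of measured compounds differs in a single place, so no measured step guides the next change. Compound 3 `CNC(=O)c1ccc(Cl)cc1-c1ccc([C@@H](C)N(CC2CC2)c2nc(C(=O)NS(=O)(=O)C3CC3)c(C3CC3)s2)cc1` differs from compound 2 by methyl in place of methoxy on an amide-type nitrogen, with the shared core otherwise unchanged. For the measured compounds named here, with no comparable step among the measured compounds, the expected step is a 1.1-fold higher number from compound 2 to compound 3 (0.03 log units; within the scatter), which amounts to no change beyond the scatter in either direction. On that basis compound 3 is expected to give about 3500 ng.h/mL, within a range from 1400 ng.h/mL to 8500 ng.h/mL.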

Compound 3, area under the concentration-time curve: 8720 ng.h/mL
Beside the measured number, compound 3's estimate is 2.5-fold (0.40 log units) below it; measured number above the stated range.
By their numbers in this assay, from the lowest: compound 2; then compounds 3 and 1 (each within the scatter of the next).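

Methyl in place of methoxy on the amide-type nitrogen gives the first single-place comparison in the series: in this assay there is a 2.7-fold higher number from compound 2 to compound 3 (0.42 log units; beyond the scatter), a modest step but beyond the scatter. The group on this nitrogen therefore matters to the read-out, which the earlier pair, differing in more than one place, could not show. Nothing at hand bears on the reason for the step.

Still open, from the compounds shown here alone, is how far the trend runs on this nitrogen: an ethyl or cyclopropyl group, a hydroxy group, or the unsubstituted amide would show whether methyl is a particular optimum or one point on a wider range. Also open, going by these compounds, is whether the same swap gives a step of similar size when other parts of the shared core change.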